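A few compounds are considered here, and "the series" means these few. Any claim that something is new, unique, unknown or untested is made for them only; others in the source may bear on it.

The series shares one core, shown in compound 1 `O=C(/C=C\c1ccccc1)N1N=C(c2ccncc2)OC1c1c[nH]c2ccccc12`. In an ADME assay on HeLa cells (Homo sapiens) for cytotoxicity, read by MTT assay, with a stated time of 72 h (a higher number here means a weaker inhibitor of growth, a lower number a stronger inhibitor of growth), compound 1 gives only a limit of the assay, > 30 ug/mL. Among the compounds with values here, compound 2 `O=C(/C=C\c1ccc(Cl)cc1Cl)N1N=C(c2ccncc2)OC1c1c[nH]c2ccccc12`, with 2,4-dichlorophenyl in place of phenyl, is the only member with a measured number: in this assay compound 2 gives 29.3 ug/mL. The step of an at least 1.0-fold lower number from compound 1 to compound 2 (0.01 log units; that floor lies within the scatter) starts from the limit (the limit of > 30 ug/mL in this assay, at which 1 of the 2 values shown sits), so it is no more than a floor, and that floor lies within the scatter. Compound 3 `O=C(/C=C\c1ccc(Br)cc1)N1N=C(c2ccncc2)OC1c1c[nH]c2ccccc12` has not yet been measured. It differs from compound 2 by 4-bromophenyl in place of 2,4-dichlorophenyl on a double-bonded chain carbon bound to a double-bonded chain carbon. Within the data shown here, the single measured step bears on this change only loosely: it begins at a limit and its floor sits within the scatter, so it points in no direction. For compound 3 the expected step of a 1.1-fold higher number from compound 2 to compound 3 (0.04 log units; within the scatter) therefore stays within the scatter, and there is a fair chance that this assay again reports only a limit. The estimate for compound 3 in this assay is 32 ug/mL, within a range from 15 ug/mL to 65 ug/mL.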

Compound 3, concentration for 50% growth inhibition: > 30 ug/mL
Compound 3 was reported as a limit; the forecaster's own chance of this, stated with the estimate: 55%; the middle value is on the limit's open side.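

In this assay, the change from 2,4-dichlorophenyl to 4-bromophenyl on a double-bonded chain carbon bound to a double-bonded chain carbon gives an at least 1.0-fold higher number from compound 2 to compound 3 (0.01 log units; that floor lies within the scatter). This step ends at a limit, so it is no more than a floor and shows no direction for the change, while the step between the two limits, compound 1 and compound 3, cannot be read. What compound 3 adds is that a single bromo on the phenyl ring joins the unsubstituted phenyl at the limit, leaving the number for compound 2 as the only measured value in the series: the limit of > 30 ug/mL in this assay, at which 2 of the 3 values shown sit.

The compounds shown leave open whether anything at this place would give a number clearly beyond the scatter from that of compound 2, since all three carry only a phenyl ring with hydrogen or halogen on it. An amine or a carboxylic acid on that ring, or a longer chain in place of the 2-(4-bromophenyl)ethenyl group, could test this, and the shared core offers no comparison here at all.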